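Swapping an Amine Arm for a Tetrazole on a Shared Core

A few compounds are considered here, and "the series" means these few. Any claim that something is new, unique, unknown or untested is made for them only; others in the source may bear on it.

Compound 1, `CC(C)CCn1c(Cn2c(=O)n(C(C)C)c3ccccc32)nc2cc(CNC3CC3)ccc21`: 17200 nM
Compound 2, `CC(C)CCn1c(Cn2c(=O)n(CC(=O)OC(C)(C)C)c3ccccc32)nc2cc(C#N)ccc21`: 32200 nM
Compound 3, `CC(=O)c1ccc2c(c1)nc(Cn1c(=O)n(C)c3ccccc31)n2CCC(C)C`: 5200 nM

These three compounds share a core and were tested in an ADME assay on HEp-2 cells (Homo sapiens) for cytotoxicity; on this read-out higher numbers stand for lower toxicity in this test and lower numbers for higher toxicity in this test. Compound 1 holds the second highest of the three numbers; compound 2 sits within the scatter of it, while compound 3 lies beyond the scatter on the low side, meaning more toxicity in this test. Compound 4, `CC(C)CCn1c(Cn2c(=O)n(C(C)C)c3ccccc32)nc2cc(-c3nn[nH]n3)ccc21`, has not been measured. It differs from compound 1 in one place: 2H-tetrazol-5-yl in place of (cyclopropylamino)methyl on an aromatic carbon. Within the data shown here, no measured pair shows this change, so the data give no step for it. A modest rise in the number, toward lower toxicity, is expected, though it may stay within the scatter. Compound 4 is expected to give 30000 nM, in the range 12000 nM to 80000 nM. The expected step is a 1.7-fold higher number from compound 1 to compound 4 (0.24 log units; within the scatter).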

Compound 4, half-maximal cytotoxic concentration: 2000 nM
Estimate against measurement, compound 4: 15-fold (1.18 log units) above; measured number below the stated range.
By their numbers in this assay, from the lowest: compound 4; then compound 3; then compounds 1 and 2 (each within the scatter of the next).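

In this assay, this position on the shared core proves far from neutral: 2H-tetrazol-5-yl in place of (cyclopropylamino)methyl gives an 8.6-fold lower number from compound 1 to compound 4 (0.93 log units; beyond the scatter) and so means more toxicity in this test. The two groups match in heavy-atom count, so that count alone does not predict the result here. No measurement shown explains why the number falls. Still open, on these data alone, is how a carboxylic acid or a primary amine at this position would read, and whether the same swap gives a similar step on compounds with other side chains.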